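Cytotoxicity on the shared core: dichlorophenoxy to phenoxy

The source may report more compounds than this note shows. Statements on the series, on what has been measured and on what is new or still open speak of the compounds shown alone.

Compound 1 `N#Cc1ccc(Nc2nc(Oc3ccc(Cl)cc3Cl)c3ccccc3n2)cc1` is the more tolerated of the two compounds measured in an ADME assay on MT4 cells (Homo sapiens) for cytotoxicity, read by MTT assay, with a stated time of 4 days (a lower number here means that less compound is tolerated, a higher number that more compound is tolerated), giving 32000 nM; compound 2 `CCCOc1cc(C#N)cc(OC)c1Oc1nc(Nc2ccc(C#N)cc2)nc2ccccc12` gives 5200 nM, a gap beyond the usual scatter. Compound 3 `N#Cc1ccc(Nc2nc(Oc3ccccc3)c3ccccc3n2)cc1`, not yet measured, differs from compound 1 by phenyl in place of 2,4-dichlorophenyl on an oxygen on an aromatic ring. Among the measured compounds shown here, no measured pair shows this change. The number for compound 3 is expected to sit close to that of compound 1, with any step a 1.3-fold higher number from compound 1 to compound 3 (0.10 log units; within the scatter) small and perhaps toward a higher number. Compound 3 is estimated at 40000 nM, within a range from 15000 nM to 100000 nM.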

Compound 3, half-maximal cytotoxic concentration: 370000 nM
The estimate for compound 3 lay 9.3-fold (0.97 log units) below the measured number; measured number above the stated range.
By their numbers in this assay, from the lowest: compound 2; then compound 1; then compound 3.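

On an oxygen on an aromatic ring, this position is far from silent in this assay: phenyl in place of 2,4-dichlorophenyl gives a 12-fold higher number from compound 1 to compound 3 (1.06 log units; beyond the scatter). Among the compounds shown here, the earlier compounds offered no single-place comparison, so this is the first step read at this position, and it shows that more compound is tolerated without the two chlorines. No measurement shown gives a reason for the step. As far as these compounds go, whether one chlorine alone carries the step remains open, as does where a phenyl bearing an amine or a carboxylic acid would fall.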